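A few compounds are considered here, and "the series" means these few. Any claim that something is new, unique, unknown or untested is made for them only; others in the source may bear on it.

Measured in a functional assay on DU-145 cells (Homo sapiens) for inhibition, read by trypan blue exclusion, with a stated time of 72 h; a lower number here means a stronger inhibitor, a higher number a weaker inhibitor:
- compound 1 `Cn1c(=O)c(S(=O)(=O)Cc2ccc(F)cc2F)cc2cnc(Nc3ccc4[nH]ccc4c3)nc21`: 1000 nM
- compound 2 `Cn1c(=O)c(S(=O)(=O)c2ccc(Br)cc2)cc2cnc(Nc3ccc4[nH]ccc4c3)nc21`: 5000 nM

Of these two compounds, compound 2 has the higher number, which makes it the weaker inhibitor of the pair. The next compound to be tested, compound 3 `Cn1c(=O)c(S(=O)(=O)c2ccc(N)cc2F)cc2cnc(Nc3ccc4[nH]ccc4c3)nc21`, has not yet been measured. It carries 4-amino-2-fluorophenyl in place of 4-bromophenyl on a sulfonyl sulfur.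

For the measured compounds named here, only one measured step offers guidance. It changes the group on the same sulfonyl sulfur and is modest in size: a 5.0-fold higher number from compound 1 to compound 2 (0.70 log units; beyond the scatter). Going by the values given here, no measured pair makes the exact swap found in compound 3, so this evidence is thin. That single step suggests that changing this group can shift the number by a modest amount. Compound 2 sits at the high end of the two values, so a move toward the lower number of compound 1 at 1000 nM seems the more likely direction, though this is far from certain.

The expected change is a 3.3-fold lower number from compound 2 to compound 3 (0.52 log units; beyond the scatter), a modest shift toward stronger inhibition. For compound 3, the estimated value in this assay is 1500 nM, with an expected range of 200 nM to 8000 nM.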

Compound 3, half-maximal inhibitory concentration: 8000 nM
Compound 3: middle estimate off by 5.3-fold (0.73 log units), on the low side; measured number inside the range.
By their numbers in this assay, from the lowest: compound 1; then compounds 2 and 3 (each within the scatter of the next).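

In this assay, the step with a 1.6-fold higher number from compound 2 to compound 3 (0.20 log units; within the scatter) shows that, on a sulfonyl sulfur whose other neighbours are aromatic carbon, these two phenyl groups give numbers that cannot be told apart, even though 4-amino-2-fluorophenyl carries a hydrogen-bond donor and a hydrogen-bond acceptor and 4-bromophenyl has neither. The other new step, an 8.0-fold higher number from compound 1 to compound 3 (0.90 log units; beyond the scatter) in the same assay, means that both phenyl compounds now stand on the weaker side of compound 1, the one with 2,4-difluorobenzyl, so the earlier gap is no longer tied to 4-bromophenyl alone. No measurement at hand explains either result.

The compounds shown leave open whether the gap to compound 1 comes from the methylene that links its ring to the sulfonyl sulfur or from the fluorines on that ring, and a 2,4-difluorophenyl or an unsubstituted benzyl group in this place would help separate the two. They also leave open whether a very different group here, such as a carboxylic acid on the phenyl ring or a simple alkyl chain, would move the number beyond the scatter.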